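Amine substituent variation in one antiproliferative series

The source may hold more compounds than are shown below. What is called first, only, known or untested is meant among the compounds shown, and "the series" means these compounds.

Measured compounds:
Compound 1 `COc1ccc(/C=C\c2cc(OC)c(OC)c(OC)c2)cc1OCc1ccc(CN2CC[C@H](C(=O)O)C2)cc1`, 6400 nM
Compound 2 `COc1ccc(/C=C\c2cc(OC)c(OC)c(OC)c2)cc1OCc1ccc(CN[C@H](C(=O)O)[C@@H](C)O)cc1`, > 10000 nM
Compound 3 `COc1ccc(/C=C\c2cc(OC)c(OC)c(OC)c2)cc1OCc1ccc(CNCCN(C)C)cc1`, 4400 nM

All three were tested in a functional assay on HepG2 cells (Homo sapiens) for antiproliferative activity, read by CCK-8 assay, with a stated time of 48 h; on this read-out lower numbers stand for stronger inhibition and higher numbers for weaker inhibition. For compound 2 the result is a limit of the assay, not a number. Among the two numbers, compound 3 holds the lower one, and its nearest neighbour is compound 1, with a 1.5-fold lower number from compound 1 to compound 3 (0.16 log units; within the scatter). The step of an at least 2.2-fold lower number from compound 2 to compound 3 (0.35 log units; beyond the scatter) is the only one here that goes beyond the scatter; the step of an at least 1.5-fold higher number from compound 1 to compound 2 (0.19 log units; that floor lies within the scatter) rests on a floor.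

Compound 4 `COc1ccc(/C=C\c2cc(OC)c(OC)c(OC)c2)cc1OCc1ccc(CNC(C)(C)C(=O)O)cc1` differs from compound 3 in one place: 1-carboxy-1-methylethyl in place of 2-(dimethylamino)ethyl on an amine nitrogen. The step of an at least 2.2-fold lower number from compound 2 to compound 3 (0.35 log units; beyond the scatter) bears on this most directly, since it ran the other way, from a carboxy-bearing amine substituent to the 2-(dimethylamino)ethyl group, and gave a lower number. Compound 1, also carrying a carboxy group, gives 6400 nM, within the scatter of compound 3. A modest rise in the number is therefore expected, a 1.8-fold higher number from compound 3 to compound 4 (0.26 log units; within the scatter), with a real chance of a limit. Compound 4 is estimated at 8000 nM, in a range from 4000 nM to 16000 nM.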

Compound 4, half-maximal inhibitory concentration: 6500 nM
The estimate for compound 4 lay 1.2-fold (0.09 log units) above the measured number; low and high end bracket the measured number.
By their numbers in this assay, from the lowest: compounds 3, 1 and 4 (each within the scatter of the next). At a limit, above all of these: compound 2.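

In this assay, 1-carboxy-1-methylethyl on the amine nitrogen gives a 1.5-fold higher number from compound 3 to compound 4 (0.17 log units; within the scatter), so this carboxy-bearing group is not told apart from 2-(dimethylamino)ethyl at this position. The open-chain and ring forms of the carboxy-bearing substituent are not told apart either, with a 1.0-fold higher number from compound 1 to compound 4 (0.01 log units; within the scatter). The step of an at least 1.5-fold lower number from compound 2 to compound 4 (0.18 log units; that floor lies within the scatter) leaves 1-carboxy-1-methylethyl and 1-carboxy-2-hydroxypropyl unseparated, and compound 2 remains a limit of the assay rather than a number: the limit of > 10000 nM in this assay, at which 1 of the 4 values shown sits.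

With the three numbers all within the scatter of one another, no ordering of these amine substituents can be drawn. On these data alone, whether a longer chain ending in a carboxylic acid, or a simple amide on this nitrogen, would move the number beyond the scatter remains open.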